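Working notes: the step from compound 3 to compound 4

The source may hold more compounds than are shown below. What is called first, only, known or untested is meant among the compounds shown, and "the series" means these compounds.

Measured so far in an ADME assay on HEK293 cells (Homo sapiens) for cytotoxicity, read by reporter gene assay and resazurin assay, with a stated time of 48 h; on this read-out higher numbers stand for lower toxicity in this test and lower numbers for higher toxicity in this test:
- compound 1 `COc1c(Br)cccc1C(=O)Nc1ccccc1`: > 100000 nM (a limit of the assay)
- compound 2 `O=C(Nc1ccc(Sc2nc3ccccc3s2)c(Cl)c1)c1cc(Br)cc(Br)c1`: > 100000 nM (a limit of the assay)
- compound 3 `O=C(Nc1ccc(Sc2nc3ccccc3s2)c(Cl)c1)c1cccc(Br)c1O`: 64000 nM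

Of the three, only compound 3 has a number rather than a limit, at 64000 nM. Compound 4 `COc1c(Br)cc(Br)cc1C(=O)Nc1ccc(Sc2nc3ccccc3s2)c(Cl)c1` is not yet measured. On the carbonyl carbon, the change is a group of 10 heavy atoms (7 carbon, 1 oxygen, 2 bromine; one six-membered aromatic ring of carbon only) in place of a group of 8 heavy atoms (6 carbon, 1 oxygen, 1 bromine; one six-membered aromatic ring of carbon only), on a carbonyl carbon. Among the measured compounds shown here, the one measured step that bears on it is an at least 1.5-fold lower number from compound 2 to compound 3 (0.19 log units; that floor lies within the scatter), and it replaces the 3,5-dibromophenyl with the 3-bromo-2-hydroxyphenyl that compound 4 gives up. Also relevant in this assay is the limit of > 100000 nM in this assay, at which 2 of the 3 values shown sit. The expected size is a 1.3-fold higher number from compound 3 to compound 4 (0.12 log units; within the scatter), toward higher numbers if anything and not beyond the scatter. A limit may be reported instead of a number. For compound 4 the estimated value is 85000 nM, with an expected range of 40000 nM to 100000 nM.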

Compound 4, half-maximal cytotoxic concentration: > 100000 nM
Compound 4: only a limit was reported; the forecaster's own chance of this, stated with the estimate: 60%; at least 1.1-fold (0.07 log units) between middle value and limit.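

The change on the carbonyl carbon gives in this assay an at least 1.5-fold higher number from compound 3 to compound 4 (0.19 log units; that floor lies within the scatter). Compound 4 gives only a limit of the assay, > 100000 nM. Among the compounds sharing this core, only compound 3, whose group carries a hydrogen-bond donor, gives a number, and the step from compound 2 to compound 4 cannot be read, as both are limits.

As far as these compounds go, the numbers behind those two limits stay open: the limit of > 100000 nM in this assay, at which 3 of the 4 values shown sit. Also open is whether an amine or a carboxylic acid on this ring would give a number.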